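Compound 3 to compound 4: a narrow series so far

The source may hold more compounds than are shown below. What is called first, only, known or untested is meant among the compounds shown, and "the series" means these compounds.

Of the compounds shown here, three have numbers so far in a functional assay on K562 cells (Homo sapiens) for cytotoxicity, read by ELISA, with a stated time of 4 days; a higher number here means a weaker inhibitor, a lower number a stronger inhibitor. Compound 1 `Cc1ccsc1-c1cc(-c2ccco2)cc(-c2ccc(Cl)cc2)n1` gives 20700 nM, compound 2 `Cc1ccsc1-c1cc(-c2ccoc2)cc(-c2ccco2)n1` gives 23300 nM, and compound 3 `Cc1ccc(-c2cc(-c3ccoc3)cc(-c3ccc(Cl)s3)n2)o1` gives 12700 nM. Compound 3 stands within the scatter of both compound 1 and compound 2, so the three values cannot be ranked. No two of these compounds differ in one place only, so the data show no effect of any single group.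

Compound 4 `Clc1ccc(-c2cc(-c3ccoc3)cc(-c3ccc(Cl)s3)n2)cc1` keeps the furan-3-yl and 5-chlorothiophen-2-yl groups of compound 3. It carries 4-chlorophenyl in place of 5-methylfuran-2-yl on an aromatic carbon, next to the ring nitrogen (4-chlorophenyl in place of 5-methylfuran-2-yl on an aromatic carbon).

No step beyond the scatter is expected in this assay, in either direction. This expectation rests on compound 1, which also carries a 4-chlorophenyl group and gives 20700 nM, and on compound 3 at 12700 nM. These two values lie within the scatter of each other. The expected size is a 1.2-fold higher number from compound 3 to compound 4 (0.07 log units; within the scatter), which stays within the scatter. For compound 4 the estimated value is 15000 nM, with an expected range of 6500 nM to 35000 nM.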

Compound 4, half-maximal inhibitory concentration: 19600 nM
Estimate against measurement, compound 4: 1.3-fold (0.12 log units) below; the measured number falls inside the stated range.
By their numbers in this assay, from the lowest: compounds 3, 4, 1 and 2 (each within the scatter of the next).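

Within the data shown here, compound 3 and compound 4 form the first pair that differs in one place only: on an aromatic carbon next to the ring nitrogen, 4-chlorophenyl stands in place of 5-methylfuran-2-yl, and in this assay this gives a 1.5-fold higher number from compound 3 to compound 4 (0.19 log units; within the scatter). With the furan-3-yl and 5-chlorothiophen-2-yl groups held fixed, the exchange of a five-membered aromatic ring with one hetero atom for a six-membered aromatic ring of carbon only therefore shows no effect that can be read at this position, although the entering group is the larger by the heavy-atom count and lacks the hydrogen-bond acceptor of the leaving group. No independent measurement bears on this result, so it stands as a bare comparison.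

The compounds shown leave open whether any group at this position can move the number beyond the scatter, for example an amine such as dimethylaminomethyl on the phenyl ring, a carboxylic acid, or a longer chain. They also leave open what a one-place change at the furan-3-yl or 5-chlorothiophen-2-yl group would do.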